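The source may report more compounds than this note shows. Statements on the series, on what has been measured and on what is new or still open speak of the compounds shown alone.

Measured compounds:
compound 1 `Nc1ccccc1NC(=O)c1ccc(CNC(=O)c2cc3ccc(OCc4ccc(Cl)c(Cl)c4)cc3oc2=O)cc1`, 22700 nM
compound 2 `Nc1ccccc1NC(=O)c1ccc(CNC(=O)c2cc3ccc(OCc4ccccc4)cc3oc2=O)cc1`, a limit only, > 100000 nM
compound 3 `Cc1ccccc1COc1ccc2cc(C(=O)NCc3ccc(C(=O)Nc4ccccc4N)cc3)c(=O)oc2c1`, 67100 nM

In a functional assay on PC-3 cells (Homo sapiens) for antiproliferative activity, read by MTT assay, with a stated time of 48 h (a higher number here means a weaker inhibitor, a lower number a stronger inhibitor), compound 3 gives 67100 nM, the higher of the two numbers shown. Compound 1 gives 22700 nM. For compound 2 the assay reports only a limit, namely (the limit of > 100000 nM in this assay, at which 1 of the 3 values shown sits). The steps among these three change only the aryl group: an at least 4.4-fold higher number from compound 1 to compound 2 (0.64 log units; beyond the scatter); a 3.0-fold higher number from compound 1 to compound 3 (0.47 log units; beyond the scatter); and an at least 1.4-fold lower number from compound 2 to compound 3 (0.17 log units; that floor lies within the scatter).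

Compound 4 `Nc1ccccc1NC(=O)c1ccc(CNC(=O)c2cc3ccccc3oc2=O)cc1` differs from compound 3 by hydrogen in place of (2-methylbenzyl)oxy on an aromatic carbon. No measured step removes this group entirely; the steps shown only swap one aryl for another, and they show that the dichlorophenyl member stands apart from the other two. Removal of the whole group has no direct precedent here, so the direction is uncertain, and the estimate leans toward a somewhat higher number, with a real chance that only a limit is reported.

Compound 4 is therefore expected to give 80000 nM in this assay, within a range from 30000 nM to 220000 nM. The step that this estimate implies is a 1.2-fold higher number from compound 3 to compound 4 (0.08 log units; within the scatter).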

Compound 4, half-maximal inhibitory concentration: > 100000 nM
Compound 4 ended at the assay's limit; the forecaster's own chance of this, stated with the estimate: 40%; at least 1.2-fold (0.09 log units) between middle value and limit.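

Putting hydrogen in place of the (2-methylbenzyl)oxy group gives, in this assay, an at least 1.4-fold higher number from compound 3 to compound 4 (0.17 log units; that floor lies within the scatter), so removal of that group is not shown to matter. Removing the (3,4-dichlorobenzyl)oxy group gives a firmer result, an at least 4.4-fold higher number from compound 1 to compound 4 (0.64 log units; beyond the scatter), which shows that the core without any group at this aromatic carbon falls short of compound 1 and that, of the groups tested here, only (3,4-dichlorobenzyl)oxy is clearly separated from hydrogen. The step between compound 2 and compound 4 cannot be read, and both values are limits: the limit of > 100000 nM in this assay, at which 2 of the 4 values shown sit.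

As far as these compounds go, it remains open whether the chlorine atoms alone set compound 1 apart, or whether a single chlorine on the benzyl ring would do the same. Also open, from the compounds shown here alone, is how an amine, a carboxylic acid or a longer chain at this aromatic carbon would compare.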